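The source may report more compounds than this note shows. Statements on the series, on what has been measured and on what is new or still open speak of the compounds shown alone.

Measured so far in an ADME assay on Raji cells (Homo sapiens) for cytotoxicity, read by luminescence, with a stated time of 72 h; on this read-out higher numbers stand for an effect only at larger amounts of compound and lower numbers for an effect already at smaller amounts:
- compound 1 `CCOC(=O)c1c(-c2cccc(Cl)c2)[nH]c2cc(OC)c(F)cc2c1=O`: > 21500 nM, a limit
- compound 2 `COc1cc2[nH]c(-c3cccc(Oc4ccccc4)c3)c(C(=O)NCCN3CCCC3)c(=O)c2cc1F`: > 21500 nM, a limit

Neither compound gives a number, and the two share one ceiling: the limit of > 21500 nM in this assay, at which 2 of the 2 values shown sit. For the measured compounds named here, compound 2 therefore stands only as a limit, with no measured step to place it against compound 1.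

The next compound is compound 3 `COc1cc2[nH]c(-c3cccc(Oc4ccccc4)c3)c(C(=O)OCCO)c(=O)c2cc1F`, which carries 2-hydroxyethoxy in place of (2-(pyrrolidin-1-yl)ethyl)amino on a carbonyl carbon. Going by the values given here, no measured step in this assay shows what such a change does, so the expectation rests on the limits alone. Compound 1, likewise an ester, also reads as a limit at > 21500 nM. No change beyond the usual scatter is expected, and the estimated step is an at least 1.0-fold lower number from compound 2 to compound 3 (0.03 log units; that floor lies within the scatter). Compound 3 is estimated at 20000 nM, with an expected range from 8000 nM to 30000 nM.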

Compound 3, half-maximal effective concentration: > 21500 nM
Compound 3 ended at the assay's limit; the forecaster's own chance of this, stated with the estimate: 70%; at least 1.0-fold (0.03 log units) between middle value and limit.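

For the compounds shown here, compound 2 and compound 3 both read only as limits in this assay, so no step between them can be read. The values shown share one ceiling: the limit of > 21500 nM in this assay, at which 3 of the 3 values shown sit. From the compounds shown here alone, whether 2-hydroxyethoxy in place of (2-(pyrrolidin-1-yl)ethyl)amino on a carbonyl carbon changes the half-maximal effective concentration at all remains open.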